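The source may hold more compounds than are shown below. What is called first, only, known or untested is meant among the compounds shown, and "the series" means these compounds.

Measured compounds:
- compound 1 `COc1cc(-c2cc(/C=C/C(=O)c3ccc(N)cc3)[nH]n2)cc(OC)c1OC`: 2850 nM
- compound 2 `COc1ccc(-c2cc(/C=C/C(=O)c3ccc(OC)c(OC)c3)[nH]n2)cc1`: "not determined" (no result reported)
- compound 3 `COc1cc(-c2cc(/C=C/C(=O)c3ccc(Cl)c(Cl)c3)[nH]n2)cc(OC)c1OC`: 13900 nM

These numbers come from a functional assay on SK-MEL-2 cells (Homo sapiens) for inhibition, read by sulforhodamine B assay, with a stated time of 48 h; a lower number here means a stronger inhibitor of growth, a higher number a weaker inhibitor of growth. Compound 1 gives the lowest number of the two that were reported; the nearest is compound 3, with a 4.9-fold higher number from compound 1 to compound 3 (0.69 log units; beyond the scatter). Compound 2 has no reported result in this assay.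

Compound 4 `COc1ccc(-c2cc(/C=C/C(=O)c3ccc(N)cc3)[nH]n2)cc1OC` is not yet measured. Compared with compound 1, the change is hydrogen in place of methoxy on an aromatic carbon. Among the compounds with values here, this change sits on the ring that carries the methoxy groups, not on the carbonyl side where the only measured step, from compound 1 to compound 3, took place. Within the data shown here, that step therefore does not speak directly to the change in hand, and no pair among the measured compounds shows what losing one methoxy group does. With nothing to lean on, a small step is the most reasonable expectation, possibly toward a higher number, and it may well lie within the scatter. For compound 4 the expected step in this assay is a 1.8-fold higher number from compound 1 to compound 4 (0.24 log units; within the scatter). Compound 4 is therefore estimated at 5000 nM, with a range from 1500 nM to 16000 nM.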

Compound 4, concentration for 50% growth inhibition: 8440 nM
The estimate for compound 4 lay 1.7-fold (0.23 log units) below the measured number; low and high end bracket the measured number.
By their numbers in this assay, from the lowest: compound 1; then compounds 4 and 3 (each within the scatter of the next).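

Replacing one methoxy group with hydrogen in this assay produces a 3.0-fold higher number from compound 1 to compound 4 (0.47 log units; beyond the scatter) and so moves the number beyond the scatter. The earlier step showed a change only on the carbonyl side, whereas this pair shows that the ring carrying the methoxy groups also matters for growth inhibition, and that this methoxy group cannot be removed without a measurable loss in compound 4. No measurement given here accounts for the size of this step.

One pair cannot show whether a hydroxyl group, a fluorine atom or an ethoxy group at this position would keep the lower number seen with methoxy. As far as these compounds go, it also remains open whether removing this methoxy group would have a similar effect with the 3,4-dichlorophenyl group on the carbonyl side.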